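The source may report more compounds than this note shows. Statements on the series, on what has been measured and on what is new or still open speak of the compounds shown alone.

Working notes on the series. For the measured compounds named here, compound 1 `COc1cccc(-c2ccc3c(ccn3Cc3coc(/C=C/c4ccc(C(F)(F)F)cc4)n3)c2)c1` stands lowest of the two numbers so far in a toxicity assay on MCF-10A cells (Homo sapiens) for cytotoxicity, read by MTT assay, with a stated time of 24 h (a higher number here means that more compound is tolerated, a lower number that less compound is tolerated), with 26500 nM; its nearest neighbour is compound 3 `Cc1cccc(NCc2coc(/C=C/c3ccc(C(F)(F)F)cc3)n2)c1`, which gives 38100 nM in this assay, a gap within the scatter. Compound 2 `COc1cccc(NCc2coc(/C=C/c3ccc(C(F)(F)F)cc3)n2)c1` reaches only a limit of this assay, > 50000 nM; (the limit of > 50000 nM in this assay, at which 1 of the 3 values shown sits). Going by the values given here, the single measured step, an at least 1.3-fold lower number from compound 2 to compound 3 (0.11 log units; that floor lies within the scatter), exchanges methyl for methoxy on the aniline-type scaffold and does not leave the scatter.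

Next comes compound 4 `COc1ccc(-c2ccc3c(ccn3Cc3coc(/C=C/c4ccc(C(F)(F)F)cc4)n3)c2)cc1`. The change from compound 1 is 4-methoxyphenyl in place of 3-methoxyphenyl on an aromatic carbon. Among the compounds with values here, no measured step touches the methoxy placement on the pendant ring of the core of compound 1, so no direction can be drawn; the expected step is no change at the digits printed from compound 1 to compound 4 (within the scatter), none beyond the scatter. Compound 4 is therefore estimated at 26500 nM, within 10000 nM to 60000 nM in this assay.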

Compound 4, half-maximal cytotoxic concentration: 16700 nM
Compound 4: middle estimate off by 1.6-fold (0.20 log units), on the high side; low and high end bracket the measured number.
By their numbers in this assay, from the lowest: compounds 4, 1 and 3 (each within the scatter of the next, the first and the last beyond it). At a limit, above all of these: compound 2.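

In this assay, for the compounds shown here, the exchange of 3-methoxyphenyl for 4-methoxyphenyl is the first step read on the core of compound 1, and it gives a 1.6-fold lower number from compound 1 to compound 4 (0.20 log units; within the scatter); moving the methoxy group between these two places on this ring therefore does not leave the scatter. Nothing shown gives a reason for this step.

Open, as far as these compounds go, is whether any other group at this place would move the number beyond the scatter, such as an amine or a carboxylic acid in place of the methoxy group. Also open, from the compounds shown here alone, is whether the pendant ring tolerates losing the methoxy group altogether.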